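The source may report more compounds than this note shows. Statements on the series, on what has been measured and on what is new or still open speak of the compounds shown alone.

Series notes. Two cores carry the same amide side chain. Compound 1 `C=C(c1ccc(OC)cc1NC(=O)CNC)c1ccc(OC)c2c1C=CC(C)(C)O2` and compound 3 `C=C(c1ccc(OC)cc1NC(=O)CNCC)c1ccc(OC)c2c1C=CC(C)(C)O2` share one core; compound 2 `C=C(c1cc(OC)c(OC)c(OC)c1)c1ccc(OC)cc1NC(=O)CNC` and the as yet unmeasured compound 4 `C=C(c1cc(OC)c(OC)c(OC)c1)c1ccc(OC)cc1NC(=O)CNCC` share the other. The difference between the two cores is not broken down here. In a functional assay on A2780 cells (Homo sapiens) for antiproliferative activity, read by MTT assay, with a stated time of 48 h (a lower number here means a stronger inhibitor, a higher number a weaker inhibitor), compound 1 gives 720 nM, compound 3 gives 2010 nM, and compound 2 gives 140 nM, the lowest of the three numbers, with both other compounds beyond the scatter from it.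

The change from compound 1 to compound 3 is methyl in place of hydrogen on a saturated chain carbon bound to an amine nitrogen; in this assay it gave a 2.8-fold higher number from compound 1 to compound 3 (0.45 log units; beyond the scatter). The same change, (methyl in place of hydrogen on a saturated chain carbon bound to an amine nitrogen), is made from compound 2 to compound 4; it occurs twice in all among these compounds, and only the first occurrence is measured. Nothing else bears on it, so the size of the expected step is taken from that single measured pair. On that basis the expectation for compound 4 is a step of a 2.7-fold higher number from compound 2 to compound 4 (0.43 log units; beyond the scatter), close to the earlier one. Compound 4 is therefore estimated at 380 nM, with a likely range from 180 nM to 800 nM.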

Compound 4, half-maximal inhibitory concentration: 450 nM
Beside the measured number, compound 4's estimate is 1.2-fold (0.07 log units) below it; low and high end bracket the measured number.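

In this assay, the change from methylamino to ethylamino on the core of compound 2 gives a 3.2-fold higher number from compound 2 to compound 4 (0.51 log units; beyond the scatter), and this step agrees with the one on the core of compound 1: the same change on two cores in this assay, a 2.8-fold higher number (0.45 log units; beyond the scatter) from compound 1 to compound 3 and a 3.2-fold higher number (0.51 log units; beyond the scatter) from compound 2 to compound 4, 1.2-fold (0.06 log units) apart, within the scatter of two such steps. On these two cores, then, the change carries over in direction and in size, and the difference between the cores leaves the step essentially untouched. Among the compounds shown here, this rests on only two pairs in a single cell assay, so it does not show that the step would hold on any further core or in another assay, and it does not explain why the number rises.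

The compounds shown carry only methylamino and ethylamino on the amide side chain, and how a primary amine, a dimethylamino group or a longer chain such as propylamino would behave on either core stays open. From the compounds shown here alone, whether the number would keep rising as the chain grows also stays open; two chain lengths fix no trend.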